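The source may report more compounds than this note shows. Statements on the series, on what has been measured and on what is new or still open speak of the compounds shown alone.

Working notes on the series in a functional assay on HCT-116 cells (Homo sapiens) for antiproliferative activity, read by sulforhodamine B assay, with a stated time of 4 days; a lower number here means a stronger inhibitor of growth, a higher number a weaker inhibitor of growth. Three secondary amides on a shared core differ only in the group on the amide nitrogen. Compound 1 `COc1cc(Cl)c(-c2nc(SCC(=O)NC3CC3)nc3[nH]cc(C#N)c23)cc1O`, with cyclopropyl, gives 1160 nM. Compound 2 `COc1cc(Cl)c(-c2nc(SCC(=O)NC(C)C)nc3[nH]cc(C#N)c23)cc1O`, with isopropyl, gives 238 nM. Compound 3 `COc1cc(Cl)c(-c2nc(SCC(=O)NC(C)(C)C)nc3[nH]cc(C#N)c23)cc1O`, with tert-butyl, gives 117 nM, the lowest of the three numbers.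

Compound 4 `COc1cc(Cl)c(-c2nc(SCC(=O)N3CCC3)nc3[nH]cc(C#N)c23)cc1O` departs from compound 3 as follows: azetidin-1-yl in place of (tert-butyl)amino on a carbonyl carbon. The measured steps that bear on this are a 9.9-fold lower number from compound 1 to compound 3 (1.00 log units; beyond the scatter), a 4.9-fold lower number from compound 1 to compound 2 (0.69 log units; beyond the scatter) and a 2.0-fold lower number from compound 2 to compound 3 (0.31 log units; beyond the scatter). Among the measured compounds shown here, compound 1 is the only measured compound with a ring on the amide nitrogen, and it has the highest number. For the measured compounds named here, no measured compound lacks the amide hydrogen, so that part of the change is untested. A step to a higher number in this assay is therefore expected, beyond the scatter and somewhat smaller than the step from the cyclopropyl amide to the tert-butyl amide. The expected change is a 6.0-fold higher number from compound 3 to compound 4 (0.78 log units; beyond the scatter). For compound 4 the estimate is 700 nM, with an estimated range of 200 nM to 2500 nM.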

Compound 4, concentration for 50% growth inhibition: 172 nM
Estimate against measurement, compound 4: 4.1-fold (0.61 log units) above; the whole stated range lies above it.
By their numbers in this assay, from the lowest: compounds 3, 4 and 2 (each within the scatter of the next, the first and the last beyond it); then compound 1.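

In this assay, azetidin-1-yl on the carbonyl carbon removes the amide hydrogen, yet the readings stay within the scatter of both closest amides: a 1.5-fold higher number from compound 3 to compound 4 (0.17 log units; within the scatter) and a 1.4-fold lower number from compound 2 to compound 4 (0.14 log units; within the scatter). In this small set, the amide hydrogen is therefore not required for a number in the range of compound 2 and compound 3. A ring at this position also does not by itself go with the highest number, as a 6.7-fold lower number from compound 1 to compound 4 (0.83 log units; beyond the scatter) lies beyond the scatter, and no measured evidence here explains the difference between these two ring-bearing groups.

Going by these compounds, whether pyrrolidin-1-yl, piperidin-1-yl or morpholin-4-yl would keep compound 4's reading remains open. An N-methyl-N-tert-butyl amide would be needed to separate removal of the amide hydrogen from ring formation.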